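From a Pyridinyl Ether to a Bromophenyl Ether

This account rests on a few compounds, and the source may have more. Where it says the series, first, only, none or still open, it means among the compounds named here.

compound 1 `O=c1cc(-n2cc(CSc3ccccc3)nn2)c2cc(Br)ccc2o1`: 15400 nM
compound 2 `O=c1cc(-n2cc(COc3ccccc3)nn2)c2cc(Br)ccc2o1`: 4990 nM
compound 3 `O=c1cc(-n2cc(COc3cccnc3)nn2)c2cc(Br)ccc2o1`: 39800 nM

In a functional assay on SW480 cells (Homo sapiens) for antiproliferative activity, read by MTT assay, with a stated time of 48 h (a higher number here means a weaker inhibitor, a lower number a stronger inhibitor), compound 3 stands highest of the three; the steps of a 2.6-fold higher number from compound 1 to compound 3 (0.41 log units; beyond the scatter) and an 8.0-fold higher number from compound 2 to compound 3 (0.90 log units; beyond the scatter) measure its distance from the other two. Compound 4 `O=c1cc(-n2cc(COc3ccccc3Br)nn2)c2cc(Br)ccc2o1` differs from compound 3 in one place: 2-bromophenyl in place of pyridin-3-yl on an oxygen on a saturated carbon. Within the data shown here, the step that bears on this is an 8.0-fold higher number from compound 2 to compound 3 (0.90 log units; beyond the scatter), since the change to compound 4 reverses the swap of a phenyl for a pyridin-3-yl on the same oxygen; a lowering of comparable size is therefore anticipated, although the added bromine has no precedent among the measured compounds. Compound 4 is expected to give 7000 nM, within 2500 nM to 20000 nM. The expected step is a 5.7-fold lower number from compound 3 to compound 4 (0.75 log units; beyond the scatter).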

Compound 4, half-maximal inhibitory concentration: 20100 nM
For compound 4 the middle estimate is 2.9-fold (0.46 log units) below the measured one, and the stated range ends below it.
By their numbers in this assay, from the lowest: compound 2; then compounds 1, 4 and 3 (each within the scatter of the next, the first and the last beyond it).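

In this assay, the added bromine is not neutral at this place: bromo in place of hydrogen on an aromatic carbon gives a 4.0-fold higher number from compound 2 to compound 4 (0.61 log units; beyond the scatter). Both a 2.0-fold lower number from compound 3 to compound 4 (0.30 log units; within the scatter) and a 1.3-fold higher number from compound 1 to compound 4 (0.12 log units; within the scatter) lie within the scatter, so the 2-bromophenyl ether no longer keeps the clear separation that the unsubstituted phenyl ether had from the other two. No measurement on hand explains this loss. The compounds shown leave open whether 2-fluorophenyl or 2-methoxyphenyl on the same oxygen would behave like 2-bromophenyl or like plain phenyl.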